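A methoxy analogue in a three-compound series

A few compounds are considered here, and "the series" means these few. Any claim that something is new, unique, unknown or untested is made for them only; others in the source may bear on it.

Three compounds share one core and differ only in the group on a single aromatic carbon. Compound 1 `Cc1ccccc1N1CCCC(=O)N1` gives 57000 nM in an assay on isolated protein for inhibition of Polyunsaturated fatty acid 5-lipoxygenase (Homo sapiens); on this read-out higher numbers stand for weaker inhibition and lower numbers for stronger inhibition. Compound 2 `CCc1ccccc1N1CCCC(=O)N1` gives 39000 nM in this assay. Compound 3 `O=C1CCCN(c2ccccc2Cl)N1` gives 99000 nM in this assay, the highest of the three numbers; against compound 1 the gap is a 1.7-fold higher number from compound 1 to compound 3 (0.24 log units; within the scatter), and against compound 2 it is a 2.5-fold higher number from compound 2 to compound 3 (0.40 log units; beyond the scatter). Between the first two compounds the step of a 1.5-fold lower number from compound 1 to compound 2 (0.16 log units; within the scatter) shows nothing beyond the scatter.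

Compound 4 `COc1ccccc1N1CCCC(=O)N1` has not been measured. It differs from compound 3 by methoxy in place of chloro on an aromatic carbon. Among the measured compounds shown here, no measured step swaps chloro for methoxy. For the measured compounds named here, the steps that bear on it are those that place chloro where an alkyl group stood on the same aromatic carbon, a 1.7-fold higher number from compound 1 to compound 3 (0.24 log units; within the scatter) and a 2.5-fold higher number from compound 2 to compound 3 (0.40 log units; beyond the scatter); read in reverse, removing chloro gave a lower number, within the scatter in one case and beyond it in the other. A modest lowering in this assay is therefore expected for compound 4, though a change no larger than the scatter is nearly as plausible. The step expected in this assay is a 2.2-fold lower number from compound 3 to compound 4 (0.34 log units; beyond the scatter). The estimate for compound 4 in this assay is 45000 nM, with a range from 15000 nM to 140000 nM.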

Compound 4, half-maximal inhibitory concentration: 204000 nM
Beside the measured number, compound 4's estimate is 4.5-fold (0.66 log units) below it; the whole stated range lies below it.
By their numbers in this assay, from the lowest: compounds 2, 1 and 3 (each within the scatter of the next, the first and the last beyond it); then compound 4.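

In this assay, methoxy on this aromatic carbon raises the number rather than lowering it, a 2.1-fold higher number from compound 3 to compound 4 (0.31 log units; beyond the scatter), and the gap widens against the alkyl groups, a 3.6-fold higher number from compound 1 to compound 4 (0.55 log units; beyond the scatter) and a 5.2-fold higher number from compound 2 to compound 4 (0.72 log units; beyond the scatter), which makes compound 4 the weakest of the four, since all three of its steps lie beyond the scatter. Among the earlier compounds the only step beyond the scatter was the one from ethyl to chloro, whereas every change to methoxy now clears it, so this position responds more clearly to the group it carries than methyl, ethyl and chloro alone could show. No supporting measurement is available to explain this rise.

The compounds shown leave open whether the higher number goes with an oxygen on this carbon or with methoxy alone, which a hydroxy or an ethoxy group at the same place would help to separate. They also leave open how an amine or a carboxylic acid would read here, and whether any group on this carbon could bring the number well under that of compound 2, 39000 nM.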